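Isopropyl on the chain carbon of compound 1

A few compounds are considered here, and "the series" means these few. Any claim that something is new, unique, unknown or untested is made for them only; others in the source may bear on it.

Compound 1 `O=C(CNC(=O)c1cc(Cl)ccc1O)Nc1cccc(Cl)c1` gives > 10000 nM in a functional assay on K562 cells (Homo sapiens) for cytotoxicity, with a stated time of 72 h (on this read-out higher numbers stand for weaker inhibition and lower numbers for stronger inhibition), a limit of the assay and not a number (the limit of > 10000 nM in this assay, at which 1 of the 2 values shown sits). Compound 2 `C[C@H](NC(=O)c1ccc(Cl)cc1O)C(=O)Nc1ccc(Cl)c(Cl)c1` gives > 12500 nM in this assay, likewise only a limit (the limit of > 12500 nM in this assay, at which 1 of the 2 values shown sits). Both values shown thus sit at limits, and compound 1 stands at one of them. Compound 3 `CC(C)[C@@H](NC(=O)c1cc(Cl)ccc1O)C(=O)Nc1cccc(Cl)c1` differs from compound 1 by isopropyl in place of hydrogen on a saturated chain carbon bound to an amide-type nitrogen and a carbonyl carbon. Among the measured compounds shown here, no measured step covers this change. In this assay the step is expected to stay within the scatter, at a step that the limit leaves unreadable from compound 1 to compound 3. Compound 3 is expected to give 15000 nM in this assay, in the range 5000 nM to 50000 nM, most likely again reported only as a limit.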

Compound 3, half-maximal inhibitory concentration: > 10000 nM
Compound 3: no number, only a limit (the forecaster's own chance of this, stated with the estimate: 75%); the middle value lies beyond the limit too.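

Among the compounds shown here, compound 1 and compound 3 both stand only as limits in this assay, so no step between them can be read. The compounds shown leave open whether isopropyl in place of hydrogen shifts the read-out at all.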